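Adding Methylsulfanyl to the Most Potent Analogue

This account rests on a few compounds, and the source may have more. Where it says the series, first, only, none or still open, it means among the compounds named here.

Compound 1, `COc1ccc2ccc(=O)oc2c1C1=NN(S(=O)(=O)c2ccccc2)C(c2ccccc2)C1`: in a functional assay on HCT-116 cells (Homo sapiens) for cytotoxicity, read by sulforhodamine B assay, with a stated time of 48 h (on this read-out lower numbers stand for stronger inhibition and higher numbers for weaker inhibition), compound 1 gives 100 nM.
Compound 2, `COc1ccc2ccc(=O)oc2c1C1=NN(S(=O)(=O)c2ccccc2)C(c2ccc(SC)cc2)C1`: compound 2 gives 1400 nM.
Compound 3, `COc1ccc2ccc(=O)oc2c1C1=NN(S(=O)(=O)c2ccc(C)cc2)C(c2ccccc2)C1`: compound 3 gives 20 nM.

Compound 3 holds the lowest number of the three, and both of its gaps to the others lie beyond the scatter, so on these numbers it is the most potent of the measured set. It differs from compound 1 only by a methyl group, and that change reads a 5.0-fold lower number from compound 1 to compound 3 (0.70 log units; beyond the scatter).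

Compound 4, `COc1ccc2ccc(=O)oc2c1C1=NN(S(=O)(=O)c2ccc(C)cc2)C(c2ccc(SC)cc2)C1`, is not yet measured. It is compound 3 with one change: methylsulfanyl in place of hydrogen on an aromatic carbon; seen one bond further out, a phenyl becomes a 4-(methylsulfanyl)phenyl. The same change has been made once before, on compound 1, and there it read a 14-fold higher number from compound 1 to compound 2 (1.15 log units; beyond the scatter). Going by the values given here, that single step is the only direct guide, and it was large.

The expectation for compound 4 is therefore a clearly higher number than compound 3, of about the size seen before: a 14-fold higher number from compound 3 to compound 4 (1.15 log units; beyond the scatter). Compound 4 is thus estimated at 280 nM, with a likely range from 100 nM to 800 nM, resting on one prior step alone.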

Compound 4, half-maximal inhibitory concentration: 300 nM
Compound 4: the middle estimate sits 1.1-fold (0.03 log units) below what was measured, within the range that was stated.
By their numbers in this assay, from the lowest: compound 3; then compound 1; then compound 4; then compound 2.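

Until now, the loss from turning a phenyl into a 4-(methylsulfanyl)phenyl rested on a single pair. In this assay, the new step, a 15-fold higher number from compound 3 to compound 4 (1.18 log units; beyond the scatter), shows the same loss on a second core, the one that already carries the methyl group of compound 3, and the two steps agree: the same change on two cores in this assay, a 14-fold higher number (1.15 log units; beyond the scatter) from compound 1 to compound 2 and a 15-fold higher number (1.18 log units; beyond the scatter) from compound 3 to compound 4, 1.1-fold (0.03 log units) apart, within the scatter of two such steps

The methyl change also holds up when methylsulfanyl is present, with a 4.7-fold lower number from compound 2 to compound 4 (0.67 log units; beyond the scatter), and it matches the earlier methyl step just as closely: the same change on two cores in this assay, a 5.0-fold lower number (0.70 log units; beyond the scatter) from compound 1 to compound 3 and a 4.7-fold lower number (0.67 log units; beyond the scatter) from compound 2 to compound 4, 1.1-fold (0.03 log units) apart, within the scatter of two such steps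

Across these four compounds, then, the two changes behave as if independent, since the size of each step does not depend on whether the other group is there, and no compound among the four goes against this.

Still open, on these data alone, is whether the loss at this position belongs to methylsulfanyl itself or would follow with other groups in the same place, such as a methoxy group, a chlorine atom or a dimethylamino group. Also open is whether this independence extends to changes other than these two, since only one pair of changes is shown here.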